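The source may hold more compounds than are shown below. What is called first, only, known or untested is meant among the compounds shown, and "the series" means these compounds.

The compounds measured in a functional assay on SK-BR-3 cells (Homo sapiens) for antiproliferative activity, read by MTT assay, with a stated time of 72 h (a lower number here means a stronger inhibitor, a higher number a weaker inhibitor), are these. Compound 1 `C/C=C1/[C@H](O[C@@H]2O[C@H](CO)[C@@H](O)[C@H](O)[C@H]2O)OC=C(C(=O)OC)[C@H]1CC(=O)NCCC` gives only a limit, > 20000 nM. Compound 2 `C/C=C1/[C@H](O[C@@H]2O[C@H](CO)[C@@H](O)[C@H](O)[C@H]2O)OC=C(C(=O)OC)[C@H]1CC(=O)O` gives only a limit, > 15000 nM. Compound 3 `C/C=C1/[C@H](O[C@@H]2O[C@H](CO)[C@@H](O)[C@H](O)[C@H]2O)OC=C(C(=O)OC)[C@H]1CC(=O)OCc1ccc2c(c1)OCCO2` gives only a limit, > 15000 nM.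

Among the compounds with values here, compound 3 therefore stands at a limit of this assay and not at a number; the same holds for the two compounds around it, so no compound among the three can be set above or below another. The three steps between them are all unreadable: a step that the two limits leave unreadable from compound 1 to compound 2, a step that the two limits leave unreadable from compound 1 to compound 3 and a step that the two limits leave unreadable from compound 2 to compound 3, each because the limit of > 15000 nM in this assay, at which 2 of the 3 values shown sit, and the limit of > 20000 nM in this assay, at which 1 of the 3 values shown sits, are the only marks the assay gives.

Compound 4 `C/C=C1/[C@H](O[C@@H]2O[C@H](CO)[C@@H](O)[C@H](O)[C@H]2O)OC=C(C(=O)OC)[C@H]1CC(=O)OCCc1ccc(OC)c(OC)c1` differs from compound 3 in one place: 3,4-dimethoxybenzyl in place of 2,3-dihydro-1,4-benzodioxin-6-yl on a saturated chain carbon bound to an oxygen next to a carbonyl group. Within the data shown here, the step that bears most closely on it is the one from compound 2 to compound 3, where an ester group was added on the oxygen next to the carbonyl group and the result stayed at a limit; the other two steps also left only limits. Among the measured compounds shown here, no measured step gives a direction or a size for exchanging one ester group for another.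

On this ground compound 4 is expected to remain at a limit as well, with an estimate of 20000 nM ranging from 8000 nM to 60000 nM. The step that the limit leaves unreadable from compound 3 to compound 4 is expected to be no larger than the scatter.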

Compound 4, half-maximal inhibitory concentration: > 15000 nM
Compound 4: no number, only a limit; the forecaster's own chance of this, stated with the estimate: 85%; the middle value is on the limit's open side.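

In this assay compound 4 gives > 15000 nM, which is a limit and not a number. Compound 2 and compound 3 also stand at limits, so neither step to compound 4 can be read. The compounds shown leave open whether any change at the ester on the shared core yields a measurable value in this assay.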